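A Methyl Group Enters a Level Series

The compounds below may be only part of what the source reports. "The series", "measured", "known", "first", "only" and "open" are said of these compounds alone.

In a functional assay on PANC-1 cells (Homo sapiens) for inhibition, read by MTT assay, with a stated time of 24 h (a higher number here means a weaker inhibitor, a lower number a stronger inhibitor), compound 1 `CC1(C)[C@H]2CC[C@]1(C)N(Cc1cn(-c3ccc(F)cc3)nn1)C(=O)C2` gives 110 nM, compound 2 `COc1ccccc1-n1cc(CN2C(=O)C[C@@H]3CC[C@@]2(C)C3(C)C)nn1` gives 120 nM and compound 3 `CC1(C)[C@H]2CC[C@]1(C)N(Cc1cn(-c3ccc(O)cc3)nn1)C(=O)C2` gives 100 nM. These three sit together, with a 1.1-fold lower number from compound 1 to compound 3 (0.04 log units; within the scatter) and a 1.2-fold lower number from compound 2 to compound 3 (0.08 log units; within the scatter), so compound 3 is not separated from the other two.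

Compound 4 `Cc1ccccc1-n1cc(CN2C(=O)C[C@@H]3CC[C@@]2(C)C3(C)C)nn1` has not yet been measured. Its difference from compound 3 is 2-methylphenyl in place of 4-hydroxyphenyl on an aromatic nitrogen. The group is exchanged on an aromatic nitrogen of the five-membered aromatic ring with 3 nitrogen. Among the compounds with values here, no measured compound carries 2-methylphenyl, so the evidence is indirect. The step that brings in 2-methoxyphenyl in place of 4-fluorophenyl is a 1.1-fold higher number from compound 1 to compound 2 (0.04 log units; within the scatter), and the step from 2-methoxyphenyl to 4-hydroxyphenyl is a 1.2-fold lower number from compound 2 to compound 3 (0.08 log units; within the scatter). Among these three compounds, no exchange of this aromatic group moved the number beyond the scatter, and none goes against that. The same is therefore expected here, in neither direction.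

The expected step is a 1.2-fold higher number from compound 3 to compound 4 (0.06 log units; within the scatter). Compound 4 is estimated at 115 nM, with an expected range of 60 nM to 220 nM.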

Compound 4, half-maximal inhibitory concentration: 250 nM
Compound 4: the middle estimate sits 2.2-fold (0.34 log units) below what was measured, outside the stated range (above it).
By their numbers in this assay, from the lowest: compounds 3, 1 and 2 (each within the scatter of the next); then compound 4.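

Within the data shown here, at this position on the aromatic nitrogen of the triazole-type ring, the choice of aromatic group is no longer without effect in this assay: the exchange gives a 2.5-fold higher number from compound 3 to compound 4 (0.40 log units; beyond the scatter), and a 2.3-fold higher number from compound 1 to compound 4 (0.36 log units; beyond the scatter), so the level seen among the earlier compounds does not extend to 2-methylphenyl. The narrowest change, methyl in place of methoxy on an aromatic carbon, is enough to leave that level, with a 2.1-fold higher number from compound 2 to compound 4 (0.32 log units; beyond the scatter). Nothing available explains this step.

On these data alone, whether an ethyl group or an amine in place of that methyl would stay with compound 4 or return to the level of compound 1, compound 2 and compound 3 remains open. Also open is whether 4-methylphenyl would follow 2-methylphenyl, as the compounds shown hold a methyl group in one place only.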